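Pyrrolidine Replaced by a Hexylsulfanyl Chain on the Core

The source may report more compounds than this note shows. Statements on the series, on what has been measured and on what is new or still open speak of the compounds shown alone.

Compound 2 `Nc1nc(N2CCCC2)c2ncn(/C=C3/CC3(CO)CO)c2n1` has been tested in an ADME assay on CCRF-HSB-2 cells (Homo sapiens) for cytotoxicity, with a stated time of 7 days; on this read-out lower numbers stand for higher toxicity in this test and higher numbers for lower toxicity in this test. In this assay compound 2 gives > 20000 nM, which is a limit of the assay and not a number. Compound 1 `Nc1nc(NCc2ccccc2)c2ncn(/C=C3/CC3(CO)CO)c2n1` shares the core and differs from compound 2 only in carrying benzylamino where compound 2 carries pyrrolidin-1-yl. In this assay compound 1 gives > 20000 nM, again a limit of the assay and not a number. The step that the two limits leave unreadable from compound 1 to compound 2 is therefore unreadable in size; both values sit at the limit of > 20000 nM in this assay, at which 2 of the 2 values shown sit.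

Compound 3 `CCCCCCSc1nc(N)nc2c1ncn2/C=C1/CC1(CO)CO` has not been measured. It differs from compound 2 by hexylsulfanyl in place of pyrrolidin-1-yl on an aromatic carbon. Among the compounds with values here, the only measured step, a step that the two limits leave unreadable from compound 1 to compound 2, touches the same place on the core, but its size is hidden by the two limits. Within the data shown here, no measured step points away from the limit, so compound 3 is expected to show a step that the limit leaves unreadable from compound 2 to compound 3 that stays within the scatter. Compound 3 is estimated at 25000 nM, with a range from 8000 nM to 80000 nM, most probably reported again as a limit of the assay.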

Compound 3, half-maximal cytotoxic concentration: 60000 nM
For compound 3 the middle estimate is 2.4-fold (0.38 log units) below the measured one; the range from low to high includes it.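

The steps from compound 1 and from compound 2 to compound 3 cannot be read in size in this assay, because the values of compound 1 and compound 2 are limits of the assay and not numbers: the limit of > 20000 nM in this assay, at which 2 of the 3 values shown sit.

The compounds shown leave open how far benzylamino, pyrrolidin-1-yl and hexylsulfanyl truly differ on the shared core, as only compound 3 has a plain number.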